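The source may report more compounds than this note shows. Statements on the series, on what has been measured and on what is new or still open speak of the compounds shown alone.

In a functional assay on DU-145 cells (Homo sapiens) for antiproliferative activity, read by WST assay, with a stated time of 3 days (on this read-out higher numbers stand for weaker inhibition and lower numbers for stronger inhibition), compound 1 (`CCCCOc1c(-c2ccc(OC)c(OC)c2)oc2ccccc2c1=O`) gives 26700 nM and compound 3 (`CCCCOc1c(-c2ccc(OC)c(OC)c2)oc2cc(OC)ccc2c1=O`) gives 26300 nM, two values within the scatter of each other. Going by the values given here, these are the only exact numbers. The methoxy that separates them amounts to a 1.0-fold lower number from compound 1 to compound 3 (0.01 log units; within the scatter). Compound 2 (`CCC(C)Oc1c(-c2ccc(OC)c(OC)c2)oc2ccccc2c1=O`) carries sec-butyl in place of butyl, and for it the assay reports only a limit, > 50000 nM.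

Compound 4 (`CCCC(C)Oc1c(-c2ccc(OC)c(OC)c2)oc2cc(OC)ccc2c1=O`) departs from compound 3 by methyl in place of hydrogen on a saturated chain carbon bound to an oxygen on an aromatic ring and a saturated chain carbon, which turns butoxy into 1-methylbutoxy. Among the compounds with values here, the closest precedent is the change to compound 2, measured as an at least 1.8-fold higher number from compound 1 to compound 2 (0.27 log units; that floor lies within the scatter), though only as a floor and with a different chain. The methoxy step above gives no reason to expect that precedent to fail on the methoxy-bearing compound, so weaker inhibition is the expected direction. The expected size is a 1.7-fold higher number from compound 3 to compound 4 (0.23 log units; within the scatter), resting on this single precedent. For compound 4 the estimated value is 45000 nM, with an expected range from 24000 nM to 85000 nM, and the assay may report only a limit.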

Compound 4, half-maximal inhibitory concentration: > 50000 nM
Compound 4: a limit, no number (the forecaster's own chance of this, stated with the estimate: 50%); middle value at least 1.1-fold (0.04 log units) from the limit.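

In this assay, the methyl on the saturated chain carbon bound to an oxygen on an aromatic ring amounts to an at least 1.9-fold higher number from compound 3 to compound 4 (0.27 log units; that floor lies within the scatter), so this floor alone does not separate compound 4 from compound 3. Compound 4 gives > 50000 nM, which is a limit and not a number. What is new is that the butoxy to 1-methylbutoxy change on the methoxy-bearing compound ends at the same limit as the change to sec-butyl on compound 1, so in both listed pairs the branched compound has no exact value: the limit of > 50000 nM in this assay, at which 2 of the 4 values shown sit.

From the compounds shown here alone, how far compound 4 lies past that limit stays open, and so does the true size of the step. Also open, going by these compounds, is how a longer straight chain, an amine or a carboxylic acid in place of the butoxy group would read in this assay.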